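The compounds below may be only part of what the source reports. "The series", "measured", "known", "first", "only" and "open" are said of these compounds alone.

Measured in a functional assay on Jurkat cells (Homo sapiens); a higher number here means a weaker inhibitor, a lower number a stronger inhibitor:
- Compound 1 `CC(C)[C@H](NC(=O)COc1cccc2ccccc12)C(=O)N[C@@H](CC(=O)O)C(=O)COC(=O)c1c(Cl)cccc1Cl`: 10600 nM
- Compound 2 `CC(C)[C@H](NC(=O)COc1cccc2ccccc12)C(=O)N[C@@H](CC(=O)O)C(=O)COc1ccc(C(F)(F)F)cc1`: > 100000 nM (a limit)
- Compound 3 `CC(C)[C@H](NC(=O)COc1cccc2ccccc12)C(=O)N[C@@H](CC(=O)O)C(=O)COc1cccc(F)c1`: > 100000 nM (a limit)

In this assay compound 3 stands at > 100000 nM, which is a limit of the assay and not a number. Compound 4 `CC(C)[C@H](NC(=O)COc1cccc2ccccc12)C(=O)N[C@@H](CC(=O)O)C(=O)COc1c(F)cccc1F` differs from it in one place: 2,6-difluorophenyl in place of 3-fluorophenyl on an oxygen on a saturated carbon. Here 2,6-difluorophenyl takes the place of 3-fluorophenyl on an oxygen on a saturated carbon, and the rest of the molecule stays the same.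

Among the measured compounds shown here, two measured steps bear on this change: an at least 9.4-fold higher number from compound 1 to compound 2 (0.97 log units; beyond the scatter) and an at least 9.4-fold higher number from compound 1 to compound 3 (0.97 log units; beyond the scatter). Both lie beyond the scatter, and both replace (2,6-dichlorophenyl)carbonyl with a phenyl group on that oxygen. Compound 4 also carries a phenyl group there, so it resembles the two compounds at the limit more closely than compound 1. The remaining comparison gives no guidance on the phenyl groups themselves: a step that the two limits leave unreadable from compound 2 to compound 3.

A modest move toward a lower number is therefore the most that can be expected, and compound 4 may well stop at the same limit. The expected change is an at least 2.5-fold lower number from compound 3 to compound 4 (0.39 log units; beyond the scatter). For compound 4 the estimated value is 40000 nM, with an expected range of 8000 nM to 100000 nM.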

Compound 4, half-maximal inhibitory concentration: 2040 nM
Compound 4: the middle estimate sits 20-fold (1.29 log units) above what was measured; the whole stated range lies above it.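

In this assay, a phenyl group on this oxygen does not by itself rule out inhibition, which compound 2 and compound 3 alone might have suggested: 2,6-difluorophenyl in place of 3-fluorophenyl gives an at least 49-fold lower number from compound 3 to compound 4 (1.69 log units; beyond the scatter), and the same group in place of 4-(trifluoromethyl)phenyl gives an at least 49-fold lower number from compound 2 to compound 4 (1.69 log units; beyond the scatter). As far as these compounds go, both steps start from a limit of the assay and not from a number, so their true size stays unknown: the limit of > 100000 nM in this assay, at which 2 of the 4 values shown sit. The change away from the carbonyl group also no longer costs activity in every case, since compound 4 gives a 5.2-fold lower number from compound 1 to compound 4 (0.72 log units; beyond the scatter), which shows that the (2,6-dichlorophenyl)carbonyl group of compound 1 is not needed for measurable inhibition in this small set, while compound 2 and compound 3 go the other way.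

The step between compound 2 and compound 3 cannot be read, so these compounds do not rank those two phenyl groups or say why 2,6-difluorophenyl differs from them. From the compounds shown here alone, whether both fluorines matter remains open, and 2-fluorophenyl, plain phenyl or 2,6-dichlorophenyl on the same oxygen would help to separate these possibilities.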